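The compounds below may be only part of what the source reports. "The series", "measured", "known", "first", "only" and "open" are said of these compounds alone.

Measured compounds:
compound 1 `COc1ccccc1CN1CC=C(CCC(=O)NO)C1=O` with 3560 nM
compound 2 `O=C(CCC1=CCN(Cc2cccc(C(F)(F)F)c2)C1=O)NO` with 880 nM

In a functional assay on PC-3 cells (Homo sapiens) for antiproliferative activity (on this read-out lower numbers stand for stronger inhibition of growth and higher numbers for weaker inhibition of growth), compound 2 stands lowest of the two numbers shown. Among the measured compounds shown here, compound 1, the only other measured compound, gives the higher number, and the gap between the two lies beyond the usual scatter of this assay. The two compounds differ in more than one place, so what their values show is only that the benzyl cap with trifluoromethyl gives the stronger growth inhibition of the two.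

Compound 3 `O=C(CCC1=CCN(Cc2ccccc2)C1=O)NO` is the next compound. Relative to compound 2 it carries the change (hydrogen in place of trifluoromethyl on an aromatic carbon). For the measured compounds named here, no pair of measured compounds separated by this single change exists, so there is no measured step to rest on; the expectation for compound 3 is drawn only from the values of compound 2 and compound 1 and from the fact that a group is lost from the cap. A moderate weakening is expected, beyond the scatter, as the step of a 1.8-fold higher number from compound 2 to compound 3 (0.26 log units; within the scatter). For compound 3 in this assay the estimated value is 1600 nM, with a range from 600 nM to 4200 nM.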

Compound 3, concentration for 50% growth inhibition: 4430 nM
Estimate against measurement, compound 3: 2.8-fold (0.44 log units) below, outside the stated range (above it).
By their numbers in this assay, from the lowest: compound 2; then compounds 1 and 3 (each within the scatter of the next).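

In this assay, the change at this position has a clear effect: hydrogen in place of trifluoromethyl, on the aromatic carbon meta to a large group, gives a 5.0-fold higher number from compound 2 to compound 3 (0.70 log units; beyond the scatter), a step beyond the scatter that now rests on a single change rather than on two compounds differing in more than one place. Hydrogen in place of methoxy gives a 1.2-fold higher number from compound 1 to compound 3 (0.09 log units; within the scatter), which lies within the scatter, so among these compounds trifluoromethyl on the cap separates from hydrogen while the methoxy of compound 1 does not. Nothing measured here gives a reason for either step, and the cause of the trifluoromethyl effect therefore stays unexplained.

The compounds shown leave open whether the stronger growth inhibition of compound 2 belongs to trifluoromethyl in particular or would also appear with a chlorine atom, a nitrile or a methoxy on that same aromatic carbon. They also leave open how trifluoromethyl would read on the other carbons of the ring, since a single placement of it stands here.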